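A few compounds are considered here, and "the series" means these few. Any claim that something is new, unique, unknown or untested is made for them only; others in the source may bear on it.

Compound 2 `CCC(=O)Nc1ccc(C[C@H]2C(=O)OC[C@@H]2Cc2ccc(OC)c(OC)c2)cc1OC` is a close relative of compound 1 `COc1cc(C[C@H]2C(=O)OC[C@@H]2Cc2ccc(OC)c(OC)c2)ccc1NC(C)=O`. In an ADME assay on A549 cells (Homo sapiens) for cytotoxicity, read by MTT assay, with a stated time of 4 days (a lower number here means a stronger inhibitor, a higher number a weaker inhibitor), compound 1 gives only a limit of the assay, > 50000 nM. In this assay compound 2 likewise gives only a limit, > 50000 nM. The step that the two limits leave unreadable from compound 1 to compound 2 therefore cannot be read, a consequence of the limit of > 50000 nM in this assay, at which 2 of the 2 values shown sit. Compound 3 `COc1ccc(Nc2ccc(C[C@H]3C(=O)OC[C@@H]3Cc3ccc(OC)c(OC)c3)cc2OC)cc1` arises from compound 2 by the change (4-methoxyphenyl in place of propanoyl on a nitrogen on an aromatic ring). For the measured compounds named here, no measured step speaks to this kind of change, and the one step that is known is unreadable, so no direction can be drawn from it. Compound 2 stands at the limit of this assay, and the change to compound 3 exchanges a short chain for an aromatic ring. For compound 3 the step of an at least 1.2-fold lower number from compound 2 to compound 3 (0.09 log units; that floor lies within the scatter) is expected to be small, and a limit again is the most likely outcome. Compound 3 is estimated at 40000 nM, within 8000 nM to 100000 nM.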

Compound 3, half-maximal inhibitory concentration: > 50000 nM
Compound 3 was reported as a limit; the forecaster's own chance of this, stated with the estimate: 60%; middle value at least 1.2-fold (0.09 log units) from the limit.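

The steps from compound 1 and from compound 2 to compound 3 cannot be read in this assay, and the reason is a single shared value: the limit of > 50000 nM in this assay, at which 3 of the 3 values shown sit.

On these data alone, whether the groups on the nitrogen change the effect on these cells at all stays open for these three compounds.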